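The source may report more compounds than this note shows. Statements on the series, on what has been measured and on what is new or still open speak of the compounds shown alone.

Among the measured compounds shown here, in a functional assay on MCF7 cells (Homo sapiens) for inhibition, read by sulforhodamine B assay, with a stated time of 48 h (a lower number here means a stronger inhibitor of growth, a higher number a weaker inhibitor of growth), compound 3 (`CC(C)(C)NCc1c(C(=O)O)nn(-c2ccccc2)c1-c1ccc(Br)cc1`) gives 293000 nM as the only single number among the compounds measured. Compound 1 (`CCOC(=O)c1nn(-c2ccccc2)c(-c2ccccc2)c1CNC(C)(C)C`) shows 81700 nM; 504000 nM (2 entries) and so offers no single number. Compound 2 (`CC(C)(C)NCc1c(C(=O)O)nn(-c2ccccc2)c1-c1ccc(F)cc1`) reaches only a limit of the assay, > 680000 nM, and no number. Compound 4 (`CC(C)(C)NCc1c(C(=O)O)nn(-c2ccccc2)c1-c1ccccc1`) differs from compound 3 by one change (hydrogen in place of bromo on an aromatic carbon), hydrogen in place of bromo on an aromatic carbon, so that 4-bromophenyl becomes phenyl. For the measured compounds named here, one measured step bears on this place: an at least 2.3-fold lower number from compound 2 to compound 3 (0.36 log units; beyond the scatter), with bromo in place of fluoro on an aromatic carbon. Going by the values given here, that step is beyond the scatter, and it is the only guide. Taking the bromo away is therefore expected to raise the number in this assay modestly, towards a weaker inhibitor of growth, and the estimated step is a 1.8-fold higher number from compound 3 to compound 4 (0.25 log units; within the scatter) in size. For compound 4 the estimated value is 520000 nM, with an expected range from 230000 nM to 1100000 nM as its ends.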

Compound 4, concentration for 50% growth inhibition: > 716000 nM
Compound 4 was reported as a limit; the forecaster's own chance of this, stated with the estimate: 45%; middle value at least 1.3-fold (0.13 log units) away from the limit.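

In this assay, the change from 4-bromophenyl to phenyl gives an at least 2.4-fold higher number from compound 3 to compound 4 (0.38 log units; beyond the scatter), so the bromo at this place is now compared with hydrogen as well as with fluoro, and in both comparisons the compound carrying the bromo has the lower number. Compound 4 is reported only as a limit, > 716000 nM, not as a number. The step between the fluoro and hydrogen compounds cannot be read, as compound 2 and compound 4 are both limits, so these two cannot be ordered.

The compounds shown leave open whether a chloro or a methoxy group at this place would give a number as low as the bromo does. They also leave open whether the 4-bromophenyl group would have the same effect alongside the ethyl ester of compound 1.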